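The source may report more compounds than this note shows. Statements on the series, on what has been measured and on what is new or still open speak of the compounds shown alone.

Measured compounds:
compound 1, `CCCCCCCCN(C)C(=O)Cn1cc(Cc2cnc(=O)n(CC(=O)N3CCOCC3)c2)c(=O)nc1SCc1ccc(F)cc1`, gives 36% in a functional assay on a cell-free system (plasma, Oryctolagus cuniculus) for inhibition of platelet-activating factor acetylhydrolase (Homo sapiens), tested at 100 nM; on this read-out higher numbers stand for more inhibition at the one concentration tested (going by the name of the read-out) and lower numbers for less inhibition.
compound 2, `CCCCCCCCN(C)C(=O)Cn1cc(Cc2cnc(=O)n(CC(=O)N3CCNC(=O)C3)c2)c(=O)nc1SCc1ccc(F)cc1`, gives 55% in this assay.
compound 3, `CCCCCCCCCCCCN(C)C(=O)Cn1cc(Cc2cnc(=O)n(CC(=O)N3CCOCC3)c2)c(=O)nc1SCc1ccc(F)cc1`, gives 30% in this assay.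

Compound 1 and compound 2 differ only by 3-oxopiperazin-1-yl in place of morpholin-4-yl on a carbonyl carbon. This change produced a number 19 percentage points higher from compound 1 to compound 2 (beyond the scatter). Compound 3 differs from compound 1 in its core by butyl in place of hydrogen on a saturated chain carbon, eight bonds along the chain from an amide-type nitrogen, which in this assay reads as a number 6 percentage points lower from compound 1 to compound 3 (within the scatter). Compound 4, `CCCCCCCCCCCCN(C)C(=O)Cn1cc(Cc2cnc(=O)n(CC(=O)N3CCNC(=O)C3)c2)c(=O)nc1SCc1ccc(F)cc1`, has not yet been measured. It stands to compound 3 as compound 2 stands to compound 1: the change is 3-oxopiperazin-1-yl in place of morpholin-4-yl on a carbonyl carbon, at the same place, so it is the same change, occurring twice among these four compounds. A step of similar size is expected in this assay because the earlier instance gave a number 19 percentage points higher from compound 1 to compound 2 (beyond the scatter). For the measured compounds named here, the expected step is a number 17 percentage points higher from compound 3 to compound 4 (beyond the scatter), resting on the single precedent and on compound 3 at 30%. For compound 4 the expected value is 47%, between 32% and 62%.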

Compound 4, a percentage reported as inhibition, at one concentration (the size of the read-out at that concentration, not a potency): 49%
Beside the measured number, compound 4's estimate is 2 percentage points below it, within the range that was stated.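

Carried onto the core of compound 3, 3-oxopiperazin-1-yl in place of morpholin-4-yl on a carbonyl carbon gave a number 19 percentage points higher from compound 3 to compound 4 (beyond the scatter) in this assay, and the step kept its size on both cores: the same change on two cores in this assay, a number 19 percentage points higher (beyond the scatter) from compound 1 to compound 2 and a number 19 percentage points higher (beyond the scatter) from compound 3 to compound 4, 0 percentage points apart, within the scatter of two such steps
Butyl in place of hydrogen on the saturated chain gave a number 6 percentage points lower from compound 2 to compound 4 (within the scatter), which also repeated: the same change on two cores in this assay, a number 6 percentage points lower (within the scatter) from compound 1 to compound 3 and a number 6 percentage points lower (within the scatter) from compound 2 to compound 4, 0 percentage points apart, within the scatter of two such steps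
Across these four compounds the two changes therefore read independently of each other, but only two cores are shown, and they differ solely in that chain, so this does not show that the step carries to other cores.

Going by these compounds, it remains open how other groups on that carbonyl carbon, such as piperazin-1-yl or dimethylamino, would read. For the compounds shown here, the same holds for a chain longer than the one in compound 3.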